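This account rests on a few compounds, and the source may have more. Where it says the series, first, only, none or still open, it means among the compounds named here.

Of the compounds shown here, three sharing one core have been measured in a functional assay on HepG2 cells (Homo sapiens) for antiproliferative activity, read by MTT assay, with a stated time of 48 h; on this read-out higher numbers stand for weaker inhibition and lower numbers for stronger inhibition: compound 1 `COc1ccc(/C=C/c2cc(OC)cc(OC)c2/C=C/C(=O)c2cccc(OC)c2)cc1` gives 11.6 ug/mL, compound 2 `CCOc1ccc(C(=O)/C=C/c2c(/C=C/c3ccc(OC)cc3)cc(OC)cc2OC)cc1` gives 8 ug/mL, and compound 3 `COc1ccc(/C=C/c2cc(OC)cc(OC)c2/C=C/C(=O)c2ccccc2)cc1` gives 6.8 ug/mL. These numbers all lie within the scatter of one another, so compound 3 cannot be set apart from either of the other two. The next compound, compound 4 `CCN(CC)c1ccc(C(=O)/C=C/c2c(/C=C/c3ccc(OC)cc3)cc(OC)cc2OC)cc1`, has diethylamino in place of hydrogen on an aromatic carbon, para to a large group, which turns phenyl into 4-(diethylamino)phenyl: diethylamino in place of hydrogen on an aromatic carbon.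

Among the measured compounds shown here, the closest precedent is compound 2, whose 4-ethoxyphenyl stands where compound 3 has phenyl. That comparison gives a 1.2-fold lower number from compound 2 to compound 3 (0.07 log units; within the scatter). The remaining comparisons, a 1.7-fold lower number from compound 1 to compound 3 (0.23 log units; within the scatter) and a 1.5-fold lower number from compound 1 to compound 2 (0.16 log units; within the scatter), also stay within the scatter. For the measured compounds named here, none of the measured compounds carries diethylamino, so this precedent is only partial and the range has to stay wide. No step beyond the scatter is therefore expected in this assay, in either direction. The expected step is a 1.1-fold higher number from compound 3 to compound 4 (0.04 log units; within the scatter). For compound 4 the estimated value is 7.5 ug/mL, with an expected range from 3 ug/mL to 18 ug/mL.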

Compound 4, half-maximal inhibitory concentration: 6.3 ug/mL
Beside the measured number, compound 4's estimate is 1.2-fold (0.08 log units) above it; the range from low to high includes it.
By their numbers in this assay, from the lowest: compounds 4, 3, 2 and 1 (each within the scatter of the next).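

Placing diethylamino on the aromatic carbon para to a large group gives a 1.1-fold lower number from compound 3 to compound 4 (0.03 log units; within the scatter) in this assay, so this position accepts a substituent of this kind, the only one shown that carries nitrogen, with no change that can be told from the scatter. The same holds when diethylamino replaces ethoxy, with a 1.3-fold lower number from compound 2 to compound 4 (0.10 log units; within the scatter), and when 4-(diethylamino)phenyl replaces 3-methoxyphenyl, with a 1.8-fold lower number from compound 1 to compound 4 (0.27 log units; within the scatter), so hydrogen, ethoxy and diethylamino at this position, and the 3-methoxyphenyl of compound 1, cannot be separated in this assay by these numbers. Nothing reported alongside these values offers an explanation for the result.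

On these data alone, whether a carboxylic acid, a primary amine or a fluorine atom at this position would move the number beyond the scatter remains open, as does the effect of a longer chain on the nitrogen than the ethyl groups of diethylamino. Also open, as far as these compounds go, is whether the same change would leave the number just as unmoved on a core other than the one shared by these four compounds.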